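The compounds below may be only part of what the source reports. "The series", "measured", "known", "first", "only" and "open" are said of these compounds alone.

Of the compounds shown here, three built on one shared core have been measured. Compound 1, `O=C(Nc1cccc(-n2cc(-c3ccncc3)c(-c3cc(O)cc(Cl)c3)n2)c1)Nc1ccc(Cl)c(C(F)(F)F)c1`, gives 91% in a functional assay on OVCAR-3 cells (Homo sapiens) for inhibition, read by sulforhodamine B assay, with a stated time of 48 h, tested at 1 uM; a lower number here means a stronger effect, a higher number a weaker effect of the compound at the concentration tested. Going by the values given here, compound 2, `O=C(Nc1cccc(-n2cc(-c3ccncc3)c(-c3cc(O)cc(Cl)c3)n2)c1)Nc1ccc(Cl)c(Cl)c1`, gives 85% in this assay, and the single step between the two is a number 6 percentage points lower from compound 1 to compound 2 (within the scatter). Compound 3, `COc1cc(Cl)cc(-c2nn(-c3cccc(NC(=O)Nc4cc(C(F)(F)F)cc(C(F)(F)F)c4)c3)cc2-c2ccncc2)c1`, gives 5% in this assay, the lowest number of the three and so the strongest effect at the concentration tested, far from the values of compound 2 and compound 1.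

Compound 4, `COc1cc(Cl)cc(-c2nn(-c3cccc(NC(=O)Nc4cccc(C(F)(F)F)c4)c3)cc2-c2ccncc2)c1`, has not yet been measured. It differs from compound 3 in one place: hydrogen in place of trifluoromethyl on an aromatic carbon. Among the compounds with values here, no measured pair shows this exact change. Within the data shown here, the only step that touches a trifluoromethyl is a number 6 percentage points lower from compound 1 to compound 2 (within the scatter), where another group took its place and the number hardly moved; here a group is removed outright, so that step is only a loose guide. Because compound 3 stands so far apart from the others with 5%, removing one of its distinguishing groups could plausibly weaken the effect, but by how much is open. The expected step is a number 35 percentage points higher from compound 3 to compound 4 (beyond the scatter). Compound 4 is therefore estimated at 40%, within a range from 5% to 85%.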

Compound 4, a percentage reported as activity, at one concentration (the size of the read-out at that concentration, not a potency): 38%
Compound 4: middle estimate off by 2 percentage points, on the high side; the range from low to high includes it.
By their numbers in this assay, from the lowest: compound 3; then compound 4; then compounds 2 and 1 (each within the scatter of the next).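

In this assay, the step of a number 33 percentage points higher from compound 3 to compound 4 (beyond the scatter) shows that this position is not indifferent: taking away one of the two trifluoromethyl groups, and leaving a hydrogen on that aromatic carbon, changes the read-out well beyond the scatter. Going by these compounds alone, the earlier step of a number 6 percentage points lower from compound 1 to compound 2 (within the scatter) could not show this, as it put chloro in place of trifluoromethyl on a different pair of compounds and the number stayed within the scatter, so the present pair is the first to show a large step tied to a trifluoromethyl group. No measurement shown here explains why this change has such an effect, so the step stands as an observation only.

The compounds shown leave open whether another group at this position, such as a chloro, a methyl, a nitrile or an amine, would give a number near that of compound 3 or near that of compound 4. They also leave open what would happen if the remaining trifluoromethyl group of compound 4 were replaced by hydrogen as well.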